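The source may hold more compounds than are shown below. What is called first, only, known or untested is meant among the compounds shown, and "the series" means these compounds.

- Compound 1 `Cc1ccc(NC(=O)CSc2nncnc2-c2cccc3ccccc23)c(Br)c1`: 166000 nM
- Compound 2 `O=C(CSc1nncnc1-c1ccccc1Cl)Nc1ccc(Cl)cc1Cl`: 51000 nM

Going by the values given here, only two compounds have been measured so far in an ADME assay on MT4 cells (Homo sapiens) for cytotoxicity, read by MTT assay; a lower number here means that less compound is tolerated, a higher number that more compound is tolerated. Compound 1 stands at the top of this small set, and its number lies above that of compound 2 by more than the usual scatter of repeat measurements. Compound 3 `O=C(CSc1nncnc1-c1cccc2ccccc12)Nc1ccccc1Br` has not yet been measured. It is made from compound 1 by one small edit, which turns the 2-bromo-4-methylphenyl group into a 2-bromophenyl group: hydrogen in place of methyl on an aromatic carbon. In plain words, hydrogen takes the place of methyl on an aromatic carbon.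

The two measured compounds differ from each other in more than one place, so neither shows what this edit alone does. With no direct evidence, and with so little changing, the expectation is modest. The expected change, a 1.2-fold lower number from compound 1 to compound 3 (0.07 log units; within the scatter), should stay within the scatter, with no clear direction. The estimated value for compound 3 is 140000 nM, with an expected range of 60000 nM to 300000 nM.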

Compound 3, half-maximal cytotoxic concentration: 87000 nM
Beside the measured number, compound 3's estimate is 1.6-fold (0.21 log units) above it; the measured number falls inside the stated range.
By their numbers in this assay, from the lowest: compounds 2, 3 and 1 (each within the scatter of the next, the first and the last beyond it).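

This is the first pair shown that differs in one place only, and in this assay hydrogen in place of methyl on the aromatic carbon gives a 1.9-fold lower number from compound 1 to compound 3 (0.28 log units; within the scatter). Going by these compounds alone, at this position, para to a large group and meta to a bromo group, the methyl group can therefore be removed without a change that stands clear of what repeat measurements would show, although a single pair gives only a first reading of this position. No measurement at hand says what lies behind this small step.

As far as these compounds go, what a group other than methyl or hydrogen would do on this carbon stays open: a methoxy group, a hydroxyl group, an amine or a carboxylic acid might give a number within the scatter of compound 1 or one well beyond it. One step also cannot tell whether the same exchange of methyl for hydrogen would read the same way on a compound that carries different groups elsewhere on the shared core.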